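The source may hold more compounds than are shown below. What is called first, only, known or untested is meant among the compounds shown, and "the series" means these compounds.

Within the data shown here, in a physicochemical assay for solubility, read by spectrophotometry, in phosphate buffer, measured as kinetic solubility, with a stated time of 18 h, at pH 7.4 (on this read-out higher numbers stand for higher solubility and lower numbers for lower solubility), compound 3 (`O=C(Nc1ccc(O)c(-c2nc3ccccc3s2)c1)c1cc([N+](=O)[O-])ccc1Cl`) gives 23 nM, the lowest of the three numbers measured so far. Compound 1 (`Cc1cc(NC(=O)c2cc([N+](=O)[O-])ccc2Cl)cc(-c2nc3ccccc3o2)c1O`) gives 90 nM, and compound 2 (`O=C(Nc1ccc(F)c(-c2nc3ccccc3s2)c1)c1cc([N+](=O)[O-])ccc1Cl`) gives 490 nM. The next structure, compound 4 (`Cc1cc(NC(=O)c2cc([N+](=O)[O-])ccc2Cl)cc(-c2nc3ccccc3s2)c1O`), is compound 3 with a single change: methyl in place of hydrogen on an aromatic carbon.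

Among the measured compounds shown here, the only measured step between two compounds that differ in one place is a 21-fold lower number from compound 2 to compound 3 (1.33 log units; beyond the scatter), which is large and beyond the usual scatter. That step puts hydroxy in place of fluoro, however, not methyl in place of hydrogen, so it gives no direct measure of the new change. Compound 1, at 90 nM, is the nearest guide, as it also carries a methyl ortho to a hydroxy group. It lacks the 1,3-benzothiazol-2-yl group of compound 4, though, so its number cannot isolate the effect of the methyl. For the measured compounds named here, with no measured pair showing this change alone, no step beyond the scatter is expected in this assay, only a slight lean towards a higher number. The expected result is a 1.3-fold higher number from compound 3 to compound 4 (0.12 log units; within the scatter). The estimate for compound 4 is 30 nM, with an expected range from 10 nM to 90 nM.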

Compound 4, solubility: 430 nM
Beside the measured number, compound 4's estimate is 14-fold (1.16 log units) below it; measured number outside the range, above it.
By their numbers in this assay, from the lowest: compound 3; then compound 1; then compounds 4 and 2 (each within the scatter of the next).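

In this assay, among these compounds, the aromatic carbon ortho to a hydroxy group proves sensitive to a very small change, as adding a methyl of just 1 heavy atom there gives a 19-fold higher number from compound 3 to compound 4 (1.27 log units; beyond the scatter) and this large step runs opposite in direction to the one earlier step, where hydroxy replaced fluoro. The earlier compounds shown here gave no view of this position on its own, and the new compound also makes the group meta to that position readable, since 1,3-benzothiazol-2-yl in place of 1,3-benzoxazol-2-yl, with the methyl and hydroxy kept, gives a 4.8-fold higher number from compound 1 to compound 4 (0.68 log units; beyond the scatter) as a modest step that still lies beyond the scatter. No measurement here explains either step, so the numbers record what happens and not why it happens.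

On these data alone, whether the rise belongs to methyl in particular remains open, as a longer chain such as ethyl, or an amine or a methoxy group, on the same aromatic carbon could give a quite different number. It also remains open whether methyl in place of hydrogen would give a similar step on a compound carrying 1,3-benzoxazol-2-yl, where only the methyl-bearing form is shown.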